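Methoxy to chloro on the aryl of a shared pyrazoline series

The source may hold more compounds than are shown below. What is called first, only, known or untested is meant among the compounds shown, and "the series" means these compounds.

Measured compounds:
compound 1 `COc1ccc(C2=NN(C3=NC(c4ccccc4)CS3)C(c3cccc4ccccc34)C2)cc1` — 9510 nM
compound 2 `COc1ccc(C2=NN(C3=NC(c4ccccc4)CS3)C(c3ccc4ccccc4c3)C2)cc1` — 7250 nM
compound 3 `O=C1CSC(N2N=C(c3ccc(Cl)cc3)CC2c2ccc3ccccc3c2)=N1` — 13200 nM

In a functional assay on BGC-823 cells (Homo sapiens) for inhibition, read by CCK-8 assay, with a stated time of 48 h (on this read-out lower numbers stand for stronger inhibition and higher numbers for weaker inhibition), compound 1 gives 9510 nM, the second highest of the three numbers. Its nearest neighbour is compound 2 with 7250 nM, the change being a 1.3-fold lower number from compound 1 to compound 2 (0.12 log units; within the scatter). Compound 3, on a different core, gives 13200 nM.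

Compound 4 `Clc1ccc(C2=NN(C3=NC(c4ccccc4)CS3)C(c3cccc4ccccc34)C2)cc1` is not yet measured. It differs from compound 1 by chloro in place of methoxy on an aromatic carbon, the place being on an aromatic carbon of a six-membered aromatic ring of carbon only, para to a large group. For the measured compounds named here, no measured step isolates this change: the only step recorded, from compound 1 to compound 2, moves the naphthyl attachment and leaves the methoxy in place, so it does not bear on it. Compound 3 carries a 4-chlorophenyl, but on another core, so its value alone cannot be read as a step. With nothing directly comparable, the expected step in this assay is a 1.1-fold higher number from compound 1 to compound 4 (0.02 log units; within the scatter), no change beyond the scatter in either direction. Compound 4 is therefore estimated at 10000 nM, with a range from 4000 nM to 25000 nM.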

Compound 4, half-maximal inhibitory concentration: 19600 nM
For compound 4 the middle estimate is 2.0-fold (0.29 log units) below the measured one; low and high end bracket the measured number.
By their numbers in this assay, from the lowest: compounds 2, 1, 3 and 4 (each within the scatter of the next, the first and the last beyond it).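

In this assay, changing 4-methoxyphenyl to 4-chlorophenyl on the shared core gives a 2.1-fold higher number from compound 1 to compound 4 (0.31 log units; beyond the scatter), a modest step but beyond the scatter, whereas moving the naphthyl attachment gives a 1.3-fold lower number from compound 1 to compound 2 (0.12 log units; within the scatter), which stays within it. The substituent on an aromatic carbon para to a large group therefore affects the read-out in this pair, with methoxy giving the lower number and so the stronger inhibition, although one pair sets no trend. Nothing available accounts for the size or direction of this step.

From the compounds shown here alone, it remains open whether the same exchange would give a similar step on the core of compound 2, which carries naphthalen-2-yl. Going by these compounds, how an amine, a hydroxyl or a carboxylic acid in this place would compare with methoxy and chloro also remains open.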